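From 2-methylphenyl to benzyl on the shared core

The source may report more compounds than this note shows. Statements on the series, on what has been measured and on what is new or still open speak of the compounds shown alone.

Values in a functional assay on MCF7 cells (Homo sapiens) for inhibition, read by CCK-8 assay, with a stated time of 48 h (a lower number here means a stronger inhibitor of growth, a higher number a weaker inhibitor of growth), are as follows

- compound 1 `Cc1ccccc1Nc1nc(Nc2ccccn2)ncc1Cl` gives 31400 nM
- compound 2 `Cc1ccccc1Nc1nc(Nc2ccc(N3CCN(C)CC3)cn2)ncc1Cl` gives 5210 nM
- compound 3 `Cc1ccccc1Nc1nc(Nc2ccc(N3CCNCC3)cn2)ncc1Cl` gives 3410 nM

Compound 2 is level with compound 3 within the scatter, and both lie clearly under compound 1. Compound 4 `CN1CCN(c2ccc(Nc3ncc(Cl)c(NCc4ccccc4)n3)nc2)CC1` has the same atoms as compound 2 joined differently benzyl in place of 2-methylphenyl on a nitrogen on an aromatic ring with benzyl in place of 2-methylphenyl on a nitrogen on an aromatic ring. The measured steps change a different place: a 6.0-fold lower number from compound 1 to compound 2 (0.78 log units; beyond the scatter) and a 9.2-fold lower number from compound 1 to compound 3 (0.96 log units; beyond the scatter) were modest and a 1.5-fold lower number from compound 2 to compound 3 (0.18 log units; within the scatter) stayed within the scatter. None of them touches this nitrogen, so the data give no direction here. The estimated change is a 1.3-fold higher number from compound 2 to compound 4 (0.13 log units; within the scatter) and so no step beyond the scatter is expected. For compound 4 the expected value is 7000 nM with a range from 2000 nM to 28000 nM as an estimate.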

Compound 4, concentration for 50% growth inhibition: 17300 nM
Estimate against measurement, compound 4: 2.5-fold (0.39 log units) below; measured number inside the range.
By their numbers in this assay, from the lowest: compounds 3 and 2 (each within the scatter of the next); then compounds 4 and 1 (each within the scatter of the next).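

Among the compounds shown here, earlier steps changed a different place, so this is the first sign that the group on this nitrogen matters in this assay. Benzyl in place of 2-methylphenyl gives a 3.3-fold higher number from compound 2 to compound 4 (0.52 log units; beyond the scatter), a modest loss of growth inhibition even though the two groups have the same atoms. No measured evidence bears on the reason for this difference.

As far as these compounds go, it remains open whether this change would have a similar effect in compound 3. Also open, from the compounds shown here alone, is how a longer chain, such as phenylethyl, would compare with benzyl on this nitrogen.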